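A few compounds are considered here, and "the series" means these few. Any claim that something is new, unique, unknown or untested is made for them only; others in the source may bear on it.

Notes on the series: in a functional assay on Glioma cells (Homo sapiens) for inhibition, read by MTT assay, with a stated time of 72 h (a lower number here means a stronger inhibitor, a higher number a weaker inhibitor), compound 1 (`C/C1=C\CC[C@@]2(C)O[C@@H]2[C@H]2OC(=O)[C@@H](CN3CCCC3)[C@@H]2C[C@H]1O`) gives 5000 nM and compound 2 (`C/C1=C\CC[C@@]2(C)O[C@@H]2[C@H]2OC(=O)[C@@H](CN3CCCCC3)[C@@H]2C[C@H]1O`) gives 4000 nM and their step is a 1.3-fold lower number from compound 1 to compound 2 (0.10 log units; within the scatter) with no real difference shown. Compound 3 (`C/C1=C\CC[C@@]2(C)O[C@@H]2[C@H]2OC(=O)[C@@H](CN3CCN(C)CC3)[C@@H]2C[C@H]1O`) stands highest of the three at 36000 nM and is the weakest. Among the measured compounds shown here, compound 4 (`C/C1=C\CC[C@@]2(C)O[C@@H]2[C@H]2OC(=O)[C@@H](CN(C)CCN(C)C)[C@@H]2C[C@H]1O`) carries (2-(dimethylamino)ethyl)(methyl)amino in place of 4-methylpiperazin-1-yl on a saturated chain carbon bound to a saturated ring carbon and no measured step opens a ring. The nearest guides are a 7.2-fold higher number from compound 1 to compound 3 (0.86 log units; beyond the scatter) and a 9.0-fold higher number from compound 2 to compound 3 (0.95 log units; beyond the scatter) and both are modest, so no step beyond the scatter is expected in this assay for this change. The estimated step is a 1.6-fold lower number from compound 3 to compound 4 (0.21 log units; within the scatter) as a slight lean only. For compound 4 the expected value is 22000 nM with an estimated range of 7000 nM to 60000 nM in these notes.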

Compound 4, half-maximal inhibitory concentration: 16000 nM
Compound 4: the middle estimate sits 1.4-fold (0.14 log units) above what was measured; low and high end bracket the measured number.
By their numbers in this assay, from the lowest: compounds 2 and 1 (each within the scatter of the next); then compound 4; then compound 3.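

In this assay, replacing the ring of 4-methylpiperazin-1-yl with the open (2-(dimethylamino)ethyl)(methyl)amino chain on this saturated chain carbon gives a 2.3-fold lower number from compound 3 to compound 4 (0.35 log units; beyond the scatter), the first ring-opening step seen at this place. The open chain still falls short of the piperidin-1-yl and pyrrolidin-1-yl groups, with a 4.0-fold higher number from compound 2 to compound 4 (0.60 log units; beyond the scatter) and a 3.2-fold higher number from compound 1 to compound 4 (0.51 log units; beyond the scatter). No available evidence bears on the origin of these steps.

Still open, as far as these compounds go, is how morpholin-4-yl or a simple dimethylamino group would stand at this place.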